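The source may hold more compounds than are shown below. What is called first, only, known or untested is meant among the compounds shown, and "the series" means these compounds.

Going by the values given here, in a functional assay on HT-29 cells (Homo sapiens) for inhibition, read by MTT assay, with a stated time of 48 h (a higher number here means a weaker inhibitor, a lower number a stronger inhibitor), no compound measured so far gives an actual number. Compound 1 (`COc1ccc(-n2c(SCc3ccc(C)cc3)nnc2-c2cc(OC)c(OC)c(OC)c2)cc1`) reads > 60000 nM, which is a limit of the assay. Compound 2 (`COc1ccc(CSc2nnc(-c3cc(OC)c(OC)c(OC)c3)n2-c2ccc(OC)cc2)cc1`) reads > 60000 nM, also a limit. Compound 3 (`COc1ccc(C(=O)CSc2nnc(-c3cc(OC)c(OC)c(OC)c3)n2-c2ccc(OC)cc2)cc1`) reads > 60000 nM, again a limit. The picture so far is therefore (the limit of > 60000 nM in this assay, at which 3 of the 3 values shown sit). Compound 4 (`COc1ccc(-n2c(SCC(=O)c3ccc(F)cc3)nnc2-c2cc(OC)c(OC)c(OC)c2)cc1`) differs from compound 3 by having fluoro in place of methoxy on an aromatic carbon, para to a large group: fluoro in place of methoxy on an aromatic carbon. The nearest evidence is a step that the two limits leave unreadable from compound 1 to compound 2, a swap on an aromatic carbon, and a step that the two limits leave unreadable from compound 2 to compound 3. Neither has a readable size, so no change beyond the scatter can be predicted. The expected change is a number no higher from compound 3 to compound 4 (the limit leaves the size open). Compound 4 is estimated at 60000 nM, with an expected range of 20000 nM to 120000 nM.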

Compound 4, half-maximal inhibitory concentration: 42500 nM
Estimate against measurement, compound 4: 1.4-fold (0.15 log units) above, and the stated range covers the measured number.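

In this assay, going by these compounds alone, compound 4 gives 42500 nM, the first actual number in this set, so fluoro in place of methoxy on this aromatic carbon, para to a large group, allows a measurable reading. This swap gives an at least 1.4-fold lower number from compound 3 to compound 4 (0.14 log units; that floor lies within the scatter), and the wider changes give an at least 1.4-fold lower number from compound 2 to compound 4 (0.14 log units; that floor lies within the scatter) and an at least 1.4-fold lower number from compound 1 to compound 4 (0.14 log units; that floor lies within the scatter). As far as these compounds go, each is only a floor, so the true size remains unknown, and the steps among compound 1, compound 2 and compound 3 cannot be read.

From the compounds shown here alone, it remains open what chloro or an amine on that same carbon would give. Also open is how far this series can move from its limit: the limit of > 60000 nM in this assay, at which 3 of the 4 values shown sit.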